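The source may report more compounds than this note shows. Statements on the series, on what has been measured and on what is new or still open speak of the compounds shown alone.

Working notes on the series built around the shared core of compound 1 `O=C(Nc1ccc(I)cc1)c1cncc(N2CC3CC(C2)N3)c1`. Within the data shown here, in an assay on cells for displacement of a labelled ligand from Neuronal acetylcholine receptor; alpha3/beta4 (Homo sapiens) (on this read-out lower numbers stand for stronger inhibition and higher numbers for weaker inhibition), compound 1 gives 103 nM, the highest of the two numbers measured so far. Among the measured compounds shown here, its nearest measured neighbour is compound 2 `O=C(Nc1ccc(F)cc1F)c1cncc(N2CC3CC(C2)N3)c1`, which in this assay gives 50 nM; the only step measured is a 2.1-fold lower number from compound 1 to compound 2 (0.31 log units; beyond the scatter), a modest change and the only guide to how the group on the amide-type nitrogen moves the read-out.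

Compound 3 `COc1cccc(NC(=O)c2cncc(N3CC4CC(C3)N4)c2)c1` has not yet been measured. It differs from compound 1 in one place: 3-methoxyphenyl in place of 4-iodophenyl on an amide-type nitrogen. For the measured compounds named here, no measured step covers this exchange; the step to compound 2 replaces the same group with a different one and is only a loose indication that the read-out tolerates change here without large swings. The step is therefore expected to be small, a 1.1-fold lower number from compound 1 to compound 3 (0.06 log units; within the scatter), in either direction. Compound 3 is estimated at 90 nM in this assay, with a range from 30 nM to 300 nM.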

Compound 3, inhibition constant: 265 nM
Estimate against measurement, compound 3: 2.9-fold (0.47 log units) below; low and high end bracket the measured number.
By their numbers in this assay, from the lowest: compound 2; then compound 1; then compound 3.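

The group on the amide-type nitrogen now moves the read-out in both directions: in this assay, 3-methoxyphenyl in place of 4-iodophenyl gives a 2.6-fold higher number from compound 1 to compound 3 (0.41 log units; beyond the scatter), opposite in direction to the step measured earlier for 2,4-difluorophenyl. Set against 2,4-difluorophenyl, the same group gives a 5.3-fold higher number from compound 2 to compound 3 (0.72 log units; beyond the scatter), the largest gap among the three compounds, so the choice of phenyl substituents at this place matters beyond the scatter. No available measurement accounts for the direction or size of these steps.

Open, going by these compounds, is whether the higher number goes with the methoxy group itself or with where it sits on the phenyl ring, since the exchange changes both at once. Also open, on these data alone, is how this read-out would respond to an amine, a carboxylic acid or a longer alkoxy chain on that ring.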